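This account rests on a few compounds, and the source may have more. Where it says the series, first, only, none or still open, it means among the compounds named here.

Working notes on the series. The shared core is that of compound 1 `Nc1nc(N2CCCC2)sc1C(=O)/C=C/c1ccc(Br)cc1`, which in a functional assay on SW480 cells (Homo sapiens) for antiproliferative activity, read by MTT assay, with a stated time of 48 h (on this read-out lower numbers stand for stronger inhibition and higher numbers for weaker inhibition), gives 15.8 ug/mL. Compound 2 `Nc1nc(N2CCCCC2)sc1C(=O)/C=C/c1ccccc1` gives 28.1 ug/mL, and compound 3 `Nc1nc(N2CCCCC2)sc1C(=O)/C=C/c1ccc(Cl)cc1` gives 29.4 ug/mL, the highest number of the three, though its gap to compound 2 and to compound 1 is within the scatter, so no order among them can be read from these numbers. For the measured compounds named here, the one single-point step measured so far, a 1.0-fold higher number from compound 2 to compound 3 (0.02 log units; within the scatter), shows that putting chloro onto the para position in place of hydrogen left the number essentially unchanged.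

The next member, compound 4 `Nc1nc(N2CCCCC2)sc1C(=O)/C=C/c1ccc(Br)cc1`, differs from compound 3 by bromo in place of chloro on an aromatic carbon. Going by the values given here, no measured step swaps one halogen for another. Compound 1 carries bromo with a smaller ring on the core, and its number against that of compound 3 is within the scatter, so the two values offer no sign that the halogen matters. The expected step is therefore none beyond the scatter, a 1.2-fold lower number from compound 3 to compound 4 (0.09 log units; within the scatter), perhaps leaning to a slightly lower number. Compound 4 is estimated at 24 ug/mL, with a range from 12 ug/mL to 48 ug/mL.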

Compound 4, half-maximal inhibitory concentration: 31.6 ug/mL
Estimate against measurement, compound 4: 1.3-fold (0.12 log units) below; low and high end bracket the measured number.
By their numbers in this assay, from the lowest: compounds 1, 2, 3 and 4 (each within the scatter of the next).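

In this assay, for the compounds shown here, the change from 4-chlorophenyl to 4-bromophenyl gives a 1.1-fold higher number from compound 3 to compound 4 (0.03 log units; within the scatter) as the first direct swap of one halogen for another at this position, and no effect of that swap can be read. Bromo in place of hydrogen gives a 1.1-fold higher number from compound 2 to compound 4 (0.05 log units; within the scatter) and so, like chloro, leaves the number inside the scatter on this aromatic carbon. Going by these compounds alone, with bromo held fixed, the first single-point comparison of the rings on the core, piperidin-1-yl in place of pyrrolidin-1-yl, gives a 2.0-fold higher number from compound 1 to compound 4 (0.30 log units; within the scatter) and also stays within the scatter.

On these data alone, whether a methoxy group or a carboxylic acid at this position, or a morpholine ring on the core, would separate from these values stays open. Nothing at hand bears on why these steps are so small.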